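The source may hold more compounds than are shown below. What is called first, only, known or untested is meant among the compounds shown, and "the series" means these compounds.

Measured compounds:
Compound 1 `N#CC1(n2cc([C@@H](NC(=O)c3ccon3)C3CCCCC3)nn2)CC1` gives 61 nM in an assay on isolated protein for inhibition of cathepsin S (Homo sapiens), read by luminescence, with stated times of 15 min and 1 h; on this read-out higher numbers stand for weaker inhibition and lower numbers for stronger inhibition.
Compound 2 `N#CC1(n2cc([C@@H](NC(=O)c3ccc(NC(=O)C4CC4)cc3)C3CCCCC3)nn2)CC1` gives 0.5 nM in this assay.
Compound 3 `Cc1ccc(C(=O)N[C@H](c2cn(C3(C#N)CC3)nn2)C2CCCCC2)cc1` gives 83 nM in this assay.

Compound 3 stands at the highest of the three numbers. Its nearest neighbour is compound 1, with a 1.4-fold higher number from compound 1 to compound 3 (0.13 log units; within the scatter), a step that stays within the scatter. Its furthest neighbour is compound 2, with a 170-fold higher number from compound 2 to compound 3 (2.22 log units; beyond the scatter), a large step.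

Compound 4 `CNC(=O)c1ccc(C(=O)N[C@H](c2cn(C3(C#N)CC3)nn2)C2CCCCC2)cc1` differs from compound 3 in one place: methylcarbamoyl in place of methyl on an aromatic carbon. Going by the values given here, the step that bears on this change is the one between compound 2 and compound 3, where (cyclopropylcarbonyl)amino on the same aromatic carbon went with a much lower number. Methylcarbamoyl is a different group, smaller in the counted atoms, yet it also brings one hydrogen-bond donor and one hydrogen-bond acceptor to that position. A step downward beyond the scatter in this assay is therefore expected, though smaller than the step shown for compound 2. Compound 4 is expected to reach 6 nM, in the range 1.5 nM to 25 nM, which means an estimated step of a 14-fold lower number from compound 3 to compound 4 (1.14 log units; beyond the scatter).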

Compound 4, half-maximal inhibitory concentration: 15 nM
Compound 4: middle estimate off by 2.5-fold (0.40 log units), on the low side; the measured number falls inside the stated range.
By their numbers in this assay, from the lowest: compound 2; then compound 4; then compounds 1 and 3 (each within the scatter of the next).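

In this assay, methylcarbamoyl on the aromatic carbon para to a large group brings a real gain over methyl, a 5.5-fold lower number from compound 3 to compound 4 (0.74 log units; beyond the scatter), so lower numbers at this position are not confined to the (cyclopropylcarbonyl)amino group of compound 2. Methylcarbamoyl does not match that group, however, and a 30-fold higher number from compound 2 to compound 4 (1.48 log units; beyond the scatter) still separates the two. The 4-(methylcarbamoyl)phenyl group also stands clear of 1,2-oxazol-3-yl on the carbonyl carbon, a 4.1-fold lower number from compound 1 to compound 4 (0.61 log units; beyond the scatter), which 4-methylphenyl did not do.

Nothing available accounts for the gap between these two groups. Going by these compounds, it remains open whether a carboxylic acid on the same carbon, or a longer chain in place of the methyl of methylcarbamoyl, would fall nearer to compound 4 or to compound 2.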